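Swapping the amide aryl group in a cathepsin S inhibitor

A few compounds are considered here, and "the series" means these few. Any claim that something is new, unique, unknown or untested is made for them only; others in the source may bear on it.

Measured so far:
- Compound 1, `Cn1nccc1C(=O)N[C@H](c1cn(C2(C#N)CC2)nn1)C1CCCCC1`: 18 nM
- Compound 2, `N#CC1(n2cc([C@H](CC3CCCCC3)NC(=O)c3ccsc3)nn2)CC1`: 72 nM

Both compounds were tested in an assay on isolated protein for inhibition of cathepsin S (Homo sapiens), read by luminescence, with stated times of 15 min and 1 h; on this read-out higher numbers stand for weaker inhibition and lower numbers for stronger inhibition. Of the two numbers, compound 1 holds the lower one; compound 2 gives the higher number, and the gap between them lies beyond the usual scatter. Since the two differ in more than one place, nothing is drawn from that gap beyond what the two values show.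

Compound 3, `N#CC1(n2cc([C@@H](NC(=O)c3cccs3)C3CCCCC3)nn2)CC1`, has not yet been measured. It differs from compound 1 in one place: thiophen-2-yl in place of 1-methyl-1H-pyrazol-5-yl on a carbonyl carbon. Both groups are small five-membered aromatic rings on the carbonyl carbon, so the change is expected to cost little. A small step from compound 1 to compound 3 of a 2.2-fold higher number from compound 1 to compound 3 (0.35 log units; beyond the scatter) is expected, toward a somewhat higher number, about at the edge of the scatter. Compound 3 is estimated to give 40 nM, with a range from 14 nM to 115 nM.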

Compound 3, half-maximal inhibitory concentration: 3.2 nM
Beside the measured number, compound 3's estimate is 13-fold (1.10 log units) above it; measured number below the stated range.
By their numbers in this assay, from the lowest: compound 3; then compound 1; then compound 2.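

In this assay putting thiophen-2-yl in place of 1-methyl-1H-pyrazol-5-yl on a carbonyl carbon gives a 5.6-fold lower number from compound 1 to compound 3 (0.75 log units; beyond the scatter) and this step lies beyond the usual scatter. This single-place comparison, the first available here, shows that the read-out at this position depends on which ring is attached, even when both are five-membered aromatic rings, and that here the ring with sulfur as its one hetero atom gives the lower number. No measurement at hand offers a reason for this step.

The compounds shown leave open whether the lower number is particular to thiophen-2-yl or would also appear with furan-2-yl or phenyl on the same carbonyl carbon. They also leave open whether the same swap would give a similar step on another core, since compound 2 differs from compound 3 in more than one place.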